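Methoxy moved to a new position on the shared core

The compounds below may be only part of what the source reports. "The series", "measured", "known", "first", "only" and "open" are said of these compounds alone.

Compound 1 `COc1ccccc1OCCNCC(O)COc1cccc2[nH]ccc12`: 89.8 nM
Compound 2 `COc1ccccc1OCCNC[C@@H](O)COc1c(OC)ccc2[nH]ccc12`: 45.8 nM

In an assay on membranes from Cerebral cortex (strain Wistar) for displacement of a labelled ligand from Adrenergic receptor alpha-1 (Rattus norvegicus), read by scintillation counting (a higher number here means a weaker inhibitor, a lower number a stronger inhibitor), compound 1 gives 89.8 nM, the higher of the two numbers; compound 2 gives 45.8 nM, which lies within the scatter of compound 1, so no order between them can be claimed. Compound 3 `COc1ccccc1OCCNCC(O)COc1ccc(OC)c2[nH]ccc12` differs from compound 1 by methoxy in place of hydrogen on an aromatic carbon. Among the measured compounds shown here, no measured pair shows this particular change, so any expectation rests on the two numbers alone. The step is expected to be a 1.3-fold lower number from compound 1 to compound 3 (0.11 log units; within the scatter), not beyond the scatter. Compound 3 is therefore estimated at 70 nM, with a range from 25 nM to 200 nM.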

Compound 3, inhibition constant: 75.8 nM
Compound 3: middle estimate off by 1.1-fold (0.03 log units), on the low side; low and high end bracket the measured number.
By their numbers in this assay, from the lowest: compounds 2, 3 and 1 (each within the scatter of the next).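

In this assay, methoxy in place of hydrogen on an aromatic carbon, ortho to a fused ring and para to a large group, gives a 1.2-fold lower number from compound 1 to compound 3 (0.07 log units; within the scatter) and so stays within the scatter. Among the compounds shown here, this is the first measured pair for this change, and it shows that the position accepts methoxy with no difference that can be told from the scatter. Nothing measured here gives a reason for this result. From the compounds shown here alone, whether an amine, a carboxylic acid or a longer alkoxy chain at the same place would give a step beyond the scatter remains open.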